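A pyrrole in place of chlorine at the cytotoxicity limit

The source may report more compounds than this note shows. Statements on the series, on what has been measured and on what is new or still open speak of the compounds shown alone.

Three compounds sharing one core were tested in a toxicity assay on NIH3T3 cells (Mus musculus) for cytotoxicity, read by resazurin assay; on this read-out lower numbers stand for an effect already at smaller amounts and higher numbers for an effect only at larger amounts of compound. Compound 1 `Clc1ccc(NCc2cncn2Cc2ccc(-c3ccccc3)cc2)cc1-c1ccccc1` gives only a limit in this assay, > 1000 nM. Compound 2 `Nc1cc(-c2ccccc2)ccc1Cn1cncc1CNc1ccc(Cl)c(-c2ccccc2)c1`, which carries amino in place of hydrogen on an aromatic carbon, also reaches only a limit, > 1000 nM. Compound 3 `Cc1cccc(-c2cccc(NCc3cncn3Cc3ccccc3)c2)c1C` likewise stops at a limit, > 1000 nM. Going by the values given here, the single step between measured compounds, a step that the two limits leave unreadable from compound 1 to compound 2, cannot be read, because the limit of > 1000 nM in this assay, at which 3 of the 3 values shown sit, holds every value recorded so far. Compound 1 therefore stands at that limit together with the other two, with no number of its own.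

Compound 4 `c1ccc(-c2ccc(Cn3cncc3CNc3ccc(-c4ccc[nH]4)c(-c4ccccc4)c3)cc2)cc1` is not yet measured. It differs from compound 1 in one place: 1H-pyrrol-2-yl in place of chloro on an aromatic carbon. Among the compounds with values here, the only measured step concerns a different change and has no readable size, so nothing beyond the scatter is expected here, and compound 4 is expected to sit where the three measured compounds already sit, at the limit of > 1000 nM in this assay, at which 3 of the 3 values shown sit. The expected step that the limit leaves unreadable from compound 1 to compound 4 is accordingly small. For compound 4 the estimate in this assay is 3000 nM, within a range from 1000 nM to 15000 nM, and it is expected most likely to be reported again only as a limit.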

Compound 4, half-maximal effective concentration: > 10000 nM
Compound 4 ended at the assay's limit; the forecaster's own chance of this, stated with the estimate: 85%; middle value at least 3.3-fold (0.52 log units) away from the limit.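

In this assay compound 4 gives > 10000 nM, which is a limit and not a number. Compound 1 also stands only at a limit, so no step can be read between compound 1 and compound 4. The compounds shown leave open at what concentration any of them would affect these cells, and whether 1H-pyrrol-2-yl in place of chloro changes that concentration.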